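The source may report more compounds than this note shows. Statements on the series, on what has been measured and on what is new or still open speak of the compounds shown alone.

Compound 1, `CCCCCCCCOc1nc(N)nc2c1ncn2/C=C1/CC1(CO)CO`: > 20000 nM
Compound 2, `CCCCCOc1nc(N)nc2c1ncn2/C=C1/CC1(CO)CO`: > 20000 nM
Compound 3, `CCOc1nc(N)nc2c1ncn2/C=C1/CC1(CO)CO`: > 20000 nM

All three compounds were tested in an ADME assay on CCRF-HSB-2 cells (Homo sapiens) for cytotoxicity, with a stated time of 7 days; a lower number here means that less compound is tolerated, a higher number that more compound is tolerated. For compound 1 the value > 20000 nM is a limit of the assay rather than a number. For compound 2 the value > 20000 nM is likewise a limit. For compound 3 the value > 20000 nM is also a limit. Compound 2 therefore stands where the whole set stands: at the limit of > 20000 nM in this assay, at which 3 of the 3 values shown sit. The three steps among them, a step that the two limits leave unreadable from compound 1 to compound 2, a step that the two limits leave unreadable from compound 1 to compound 3 and a step that the two limits leave unreadable from compound 2 to compound 3, are all unreadable for the same reason, so nothing can be said about how the length of the chain on the oxygen shapes this read-out.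

Compound 4, `CC(C)Sc1nc(N)nc2c1ncn2/C=C1/CC1(CO)CO`, has not yet been measured in this assay. It differs from compound 2 in one place: isopropylsulfanyl in place of pentyloxy on an aromatic carbon. Going by the values given here, none of the measured steps bears on this change in a readable way; the only guidance is that every compound shares the limit. Compound 4 is therefore expected to show a step that the limit leaves unreadable from compound 2 to compound 4, that is, none beyond the scatter. Compound 4 is estimated at 30000 nM in this assay, within the range 10000 nM to 100000 nM, and most probably it will again return only a limit.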

Compound 4, half-maximal cytotoxic concentration: 94000 nM
Beside the measured number, compound 4's estimate is 3.1-fold (0.50 log units) below it; the range from low to high includes it.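

In this assay compound 4 gives 94000 nM as a number. Compounds 1, 2 and 3 each remain at a limit, so no step from any of them to compound 4 can be read: the limit of > 20000 nM in this assay, at which 3 of the 4 values shown sit.

The compounds shown leave open whether the length of the chain on the oxygen, or isopropylsulfanyl in its place, makes any difference to this read-out.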